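The source may hold more compounds than are shown below. What is called first, only, known or untested is meant among the compounds shown, and "the series" means these compounds.

Values measured in a physicochemical assay for lipophilicity, read by HPLC, measured as chromatographic lipophilicity, at pH 7.4 (a higher number here means a more lipophilic compound, a lower number a more polar compound), for the series:
Compound 1 `COc1cccc(NC(=O)c2nnn(Cc3ccncc3)c2N)c1` gives 1.4
Compound 2 `COc1cccc(NC(=O)c2nnn(CC3CCN(C(C)=O)CC3)c2N)c1` gives 1.2
Compound 3 `COc1cccc(NC(=O)c2nnn(CC3CCNCC3)c2N)c1` gives 0.6

Compound 3 holds the lowest of the three numbers in this assay and lies beyond the scatter from both other compounds. Compound 4 `COc1cccc(NC(=O)c2nnn(CC3CCN(C(=O)OC(C)(C)C)CC3)c2N)c1` has not been measured. It differs from compound 3 by tert-butoxycarbonyl in place of hydrogen on an amine nitrogen in a ring. The closest measured change is a number 0.60 log units lower from compound 2 to compound 3 (beyond the scatter), where hydrogen replaces acetyl on that same nitrogen. Read in reverse, it points upward when a group replaces the hydrogen. The steps of a number 0.20 log units lower from compound 1 to compound 2 (within the scatter) and a number 0.80 log units lower from compound 1 to compound 3 (beyond the scatter) replace pyridin-4-yl and bear on this change less directly. The entering group is larger than acetyl, so a rise of greater size than that reversed step is expected. The estimated move is a number 1.80 log units higher from compound 3 to compound 4 (beyond the scatter) and lies beyond the scatter. For compound 4 the expected value is 2.4 with an estimated range from 1.9 to 2.9 in this assay when measured.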

Compound 4, distribution coefficient: 2.9
Estimate against measurement, compound 4: 0.50 log units below, and the stated range covers the measured number.
By their numbers in this assay, from the lowest: compound 3; then compounds 2 and 1 (each within the scatter of the next); then compound 4.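

Working in this assay, the amine nitrogen in the ring carries a far larger swing than the acetyl and hydrogen pair alone showed, with a number 2.30 log units higher from compound 3 to compound 4 (beyond the scatter) against a number 0.60 log units lower from compound 2 to compound 3 (beyond the scatter) for removal of acetyl. With a carbonyl on that nitrogen in both compounds, a number 1.70 log units higher from compound 2 to compound 4 (beyond the scatter) when only the group on the carbonyl carbon changes, so the outer group matters here and not just the presence of a carbonyl. No available data explain the size of either step.

Open, as far as these compounds go, is how the number moves with methoxy or ethoxy on the same carbonyl carbon, which would fill the span between methyl and tert-butoxy. Also open, from the compounds shown here alone, is where a benzyl group directly on the ring nitrogen, with no carbonyl, would fall relative to these compounds.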